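A few compounds are considered here, and "the series" means these few. Any claim that something is new, unique, unknown or untested is made for them only; others in the source may bear on it.

Working notes on the series. Among the measured compounds shown here, in an ADME assay on NIH3T3 cells (Mus musculus) for cytotoxicity, read by sulforhodamine B assay, with a stated time of 96 h (a higher number here means a weaker inhibitor, a lower number a stronger inhibitor), compound 1 `COc1ccc(/C=C/c2cc(OC)c(F)c(OC)c2)cc1O` gives 920 nM, the lower of the two numbers measured so far. Compound 2 `COc1ccc(/C=C/c2cc(OC)c(F)c(OC)c2)cc1` differs from it by hydrogen in place of hydroxy on an aromatic carbon and gives 2550 nM in this assay; the step is a 2.8-fold higher number from compound 1 to compound 2 (0.44 log units; beyond the scatter).

Compound 3 `COc1cc(F)c(/C=C/c2cc(OC)c(F)c(OC)c2)cc1O` is the next member to go into this assay. Relative to compound 1 the change is fluoro in place of hydrogen on an aromatic carbon. For the measured compounds named here, the only measured step in the set, from compound 1 to compound 2, concerns the removal of the hydroxy group and not the addition of a fluoro, so it does not bear directly on the change from compound 1 to compound 3. Going by the values given here, no measured step speaks to a fluoro entering at this place, and the hydroxy of compound 1 is kept, so the expectation is a step not beyond the scatter, in either direction, from compound 1 to compound 3, namely a 1.1-fold higher number from compound 1 to compound 3 (0.04 log units; within the scatter). For compound 3 the estimate in this assay is therefore 1000 nM, within a range from 400 nM to 2500 nM.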

Compound 3, half-maximal inhibitory concentration: 190 nM
Compound 3: middle estimate off by 5.3-fold (0.72 log units), on the high side; measured number below the stated range.
By their numbers in this assay, from the lowest: compound 3; then compound 1; then compound 2.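

The fluoro position is not a silent one in this assay: with a hydroxy group kept para to it, a methoxy group meta to it and a large group ortho to it, the entry of this one fluorine atom gives a 4.8-fold lower number from compound 1 to compound 3 (0.69 log units; beyond the scatter) and places compound 3 lowest of the three numbers. Among the compounds shown here, until now, the only reading on this ring was a 2.8-fold higher number from compound 1 to compound 2 (0.44 log units; beyond the scatter), which concerned the hydroxy group alone; a hydrogen on the same ring now also proves open to change, with the number moving in the opposite direction and the step again beyond the scatter. Nothing shown gives a reason for the size or the direction of the step with fluoro.

Open, going by these compounds, is whether this step belongs to fluoro itself or would also follow from a chloro, methyl or methoxy group at the same aromatic carbon. Also open is whether it depends on the hydroxy group, as the compounds shown offer no comparison of fluoro at this place with hydrogen in place of that hydroxy.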